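Methoxy Replaces Methyl: From Compound 3 to Compound 4

The compounds below may be only part of what the source reports. "The series", "measured", "known", "first", "only" and "open" are said of these compounds alone.

Of the compounds shown here, three built on one shared core have been tested in a functional assay on HT-29 cells (Homo sapiens) for cytotoxicity, read by sulforhodamine B assay; on this read-out lower numbers stand for higher toxicity in this test and higher numbers for lower toxicity in this test. Compound 1, `CC1=CC[C@@H]([C@@](C)(O)CCCC(C)(C)NC(=S)NN)CC1`, reaches only a limit of the assay, > 100000 nM. Compound 2, `CC1=CC[C@@H]([C@@](C)(O)CCCC(C)(C)NC(=S)N/N=C\c2ccccc2)CC1`, gives 57400 nM in this assay. Compound 3, `CC1=CC[C@@H]([C@@](C)(O)CCCC(C)(C)NC(=S)N/N=C\c2ccc(C)cc2)CC1`, likewise returns only a limit of the assay, > 100000 nM. Compound 3 therefore stands at the limit of > 100000 nM in this assay, at which 2 of the 3 values shown sit. Among the measured steps, an at least 1.7-fold lower number from compound 1 to compound 2 (0.24 log units; that floor lies within the scatter), a step that the two limits leave unreadable from compound 1 to compound 3, and an at least 1.7-fold higher number from compound 2 to compound 3 (0.24 log units; that floor lies within the scatter).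

Compound 4, `COc1ccc(/C=N\NC(=S)NC(C)(C)CCC[C@](C)(O)[C@@H]2CC=C(C)CC2)cc1`, differs from compound 3 by methoxy in place of methyl on an aromatic carbon. For the measured compounds named here, the only measured step on that aromatic carbon, an at least 1.7-fold higher number from compound 2 to compound 3 (0.24 log units; that floor lies within the scatter), exchanged hydrogen for methyl, not methyl for methoxy, and no measured compound carries a methoxy group. With compound 3 itself at a limit, the step that the limit leaves unreadable from compound 3 to compound 4 is expected to stay within the scatter, with the outcome most likely a limit once more. Compound 4 is accordingly estimated at 120000 nM, within a range from 40000 nM to 400000 nM.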

Compound 4, concentration lethal to 50% of the cells: > 100000 nM
Compound 4: only a limit was reported (the forecaster's own chance of this, stated with the estimate: 65%); the middle value lies beyond the limit too.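

Methoxy on this aromatic carbon behaves as methyl did in this assay, and the series now gathers at one limit of the assay: the limit of > 100000 nM in this assay, at which 3 of the 4 values shown sit. For the compounds shown here, the one new step that can be read, set against hydrogen on the same carbon, is an at least 1.7-fold higher number from compound 2 to compound 4 (0.24 log units; that floor lies within the scatter), so a second group at this place, one that adds an oxygen, also fails to give a number. The other two new steps have limits at both ends and cannot be read, so compound 3 and compound 4 cannot be placed in any order.

The compounds shown leave open whether a different group on this carbon, such as chlorine, an amine or a carboxylic acid, would give a number in this assay. They also leave open how far beyond the limit compound 3 and compound 4 lie.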